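Head-group variation and SPNS2 inhibition in a small series

The source may report more compounds than this note shows. Statements on the series, on what has been measured and on what is new or still open speak of the compounds shown alone.

Compound 1 `CCCCCCCCCCc1ccc(-c2noc(CC3CNC3)n2)cc1` gives 63% in an assay on HeLa cells for inhibition of sphingosine-1-phosphate transporter SPNS2 (Mus musculus), read by LC-MS, tested at 2 uM; on this read-out higher numbers stand for more inhibition at the one concentration tested (going by the name of the read-out) and lower numbers for less inhibition.
Compound 2 `CCCCCCCCCCc1ccc(-c2noc(CC(CN)OC(C)=O)n2)cc1` gives 0%.
Compound 3 `CCCCCCCCCCc1ccc(-c2noc([C@@H](N)CCCN)n2)cc1` gives 40%.

Among these three, compound 3 stands second highest: its nearest neighbour is compound 1, with a number 23 percentage points lower from compound 1 to compound 3 (beyond the scatter), and the furthest is compound 2, with a number 40 percentage points higher from compound 2 to compound 3 (beyond the scatter). Compound 4 `CCCCCCCCCCc1ccc(-c2noc(CC(O)CNCC)n2)cc1` is not yet measured. Relative to compound 3 it carries 3-(ethylamino)-2-hydroxypropyl in place of 1,4-diaminobutyl on an aromatic carbon. Going by the values given here, two measured steps bear on this change, as both alter the same group on the shared core. The step of a number 23 percentage points lower from compound 1 to compound 3 (beyond the scatter) was modest, whereas a number 63 percentage points lower from compound 1 to compound 2 (beyond the scatter) was large, the open chain with two oxygen atoms in compound 2 ending at 0%. Compound 4 likewise carries an open chain bearing one oxygen and one nitrogen, as the name 3-(ethylamino)-2-hydroxypropyl shows, so it falls between these two precedents. The step of a number 15 percentage points lower from compound 3 to compound 4 (beyond the scatter) is therefore expected to be downward and of moderate size, with considerable uncertainty. Compound 4 is estimated at 25%, in a range from 0% to 55%.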

Compound 4, a percentage reported as inhibition, at one concentration (the size of the read-out at that concentration, not a potency): 5%
Compound 4: the middle estimate sits 20 percentage points above what was measured; the measured number falls inside the stated range.
By their numbers in this assay, from the lowest: compounds 2 and 4 (each within the scatter of the next); then compound 3; then compound 1.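

In this assay, 3-(ethylamino)-2-hydroxypropyl in place of 1,4-diaminobutyl brings a large loss (a number 35 percentage points lower from compound 3 to compound 4 (beyond the scatter)), even though the two groups have the same computed counts of hydrogen-bond donors and hydrogen-bond acceptors, so those counts alone do not set the read-out at this position. The open chains with oxygen on them cannot be told apart (a number 5 percentage points higher from compound 2 to compound 4 (within the scatter)), which means a second such chain now sits at the low end of the series, something a single example could not show. Azetidin-3-yl keeps a wide lead over 2-(ethylamino)-1-hydroxyethyl on the saturated chain carbon (a number 58 percentage points lower from compound 1 to compound 4 (beyond the scatter)), yet open chains as such are not ruled out, since compound 3 carries one and stays well clear of the two low compounds.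

Nothing measured here accounts for the loss. Also open is which part of the new chain matters, as the compounds shown do not separate the hydroxyl from the ethyl on the amine, and neither a primary amine in place of the ethylamino group nor a pyrrolidine in place of the azetidine is among them.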